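Aryl versus alkyl alkyne on the core of compound 2

The source may report more compounds than this note shows. Statements on the series, on what has been measured and on what is new or still open speak of the compounds shown alone.

Compound 2 `CCCCCCCCC#Cc1cn(C/C=C\CN2C(=O)c3ccccc3C2=O)c(=O)[nH]c1=O` in a functional assay on SW-620 cells (Homo sapiens) for antiproliferative activity, read by MTT assay, with a stated time of 3 days (on this read-out higher numbers stand for weaker inhibition and lower numbers for stronger inhibition), gives 67000 nM. Its double-bond isomer, compound 3 `CCCCCCCCC#Cc1cn(C/C=C/CN2C(=O)c3ccccc3C2=O)c(=O)[nH]c1=O`, gives 87000 nM in this assay; the step of a 1.3-fold higher number from compound 2 to compound 3 (0.11 log units; within the scatter) rests only on (the fact that compounds 2 and 3 differ only in the configuration as drawn). Compound 1 `Cc1ccc(C#Cc2cn(C/C=C\CN3C(=O)c4ccccc4C3=O)c(=O)[nH]c2=O)cc1` in this assay reaches only the limit > 100000 nM. Compound 4 `CCCCCc1ccc(C#Cc2cn(C/C=C\CN3C(=O)c4ccccc4C3=O)c(=O)[nH]c2=O)cc1` is not yet measured; it differs from compound 2 by 4-pentylphenyl in place of octyl on a triple-bonded carbon. Among the compounds with values here, the only step that bears on this is an at least 1.4-fold lower number from compound 1 to compound 2 (0.17 log units; that floor lies within the scatter), where the number sits at the limit of > 100000 nM in this assay, at which 1 of the 3 values shown sits, so the size of that step is unknown beyond its floor. Returning an aryl group on the triple-bonded carbon is therefore expected to give, for compound 4, a step of a 1.3-fold higher number from compound 2 to compound 4 (0.10 log units; within the scatter) in this assay that may not exceed the scatter. Compound 4 is estimated at 85000 nM, between 35000 nM and 200000 nM.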

Compound 4, half-maximal inhibitory concentration: > 100000 nM
Compound 4 ended at the assay's limit (the forecaster's own chance of this, stated with the estimate: 35%); middle value at least 1.1-fold (0.07 log units) from the limit.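

On these data alone, replacing octyl with 4-pentylphenyl on the triple-bonded carbon gives an at least 1.4-fold higher number from compound 2 to compound 4 (0.17 log units; that floor lies within the scatter) in this assay, a floor only, so the true size of this change stays unknown. The longer aryl substituent does not bring the aryl series to a readable number. The step between the two aryl compounds cannot be read, with compound 1 and compound 4 both at the limit: the limit of > 100000 nM in this assay, at which 2 of the 4 values shown sit.

As far as these compounds go, it remains open whether a decyl chain on the triple-bonded carbon would give a step from compound 2 beyond the scatter. The same holds for a chain ending in an amine or a carboxylic acid.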